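The compounds below may be only part of what the source reports. "The series", "measured", "known", "first", "only" and "open" are said of these compounds alone.

Measured compounds in the series:
compound 1 `N#Cc1ccccc1-c1cc(-c2cc(Cl)cc(OCCC(F)(F)F)c2)c(=O)n(-c2cccnc2)c1` — in a physicochemical assay for solubility, using the shake flask method, with a stated time of 48 h, at pH 6.5 (a higher number here means a more soluble compound, a lower number a less soluble compound), compound 1 gives 25 ug/mL
compound 2 `Cn1cc(-c2cc(-c3cc(Cl)cc(OCC4CC4)c3)c(=O)n(-c3cccnc3)c2)c(=O)[nH]c1=O` — in this assay compound 2 gives 14.2 ug/mL

Compound 2 stands at the lower of the two numbers; its nearest neighbour is compound 1, whose number is higher by an amount within the scatter, so no order between the two can be claimed. Among the measured compounds shown here, compound 1 and compound 2 differ in more than one place, and no single-point step between measured compounds exists in this set.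

Compound 3 `Cn1cc(-c2cc(-c3cc(Cl)cc(OCCC(F)(F)F)c3)c(=O)n(-c3cccnc3)c2)c(=O)[nH]c1=O` is not yet measured. It differs from compound 2 in one place: 2,2,2-trifluoroethyl in place of cyclopropyl on a saturated chain carbon bound to an oxygen on an aromatic ring. The group that leaves and the group that enters both carry no hydrogen-bond donors, no acceptors and no charge. For the measured compounds named here, no measured pair isolates this swap, so the expected step of a 1.1-fold higher number from compound 2 to compound 3 (0.02 log units; within the scatter) is small, with no clear direction beyond the scatter. Compound 3 is therefore expected near 15 ug/mL, in the range 6 ug/mL to 35 ug/mL.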

Compound 3, solubility: 57 ug/mL
Estimate against measurement, compound 3: 3.8-fold (0.58 log units) below; the whole stated range lies below it.
By their numbers in this assay, from the lowest: compounds 2 and 1 (each within the scatter of the next); then compound 3.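

In this assay, among the compounds shown here, the chain on the oxygen is not a silent position: 2,2,2-trifluoroethyl in place of cyclopropyl gives a 4.0-fold higher number from compound 2 to compound 3 (0.60 log units; beyond the scatter) and so supplies the first single-place step. With 3,3,3-trifluoropropoxy held fixed, the second place also reads, as the group of 9 heavy atoms in place of the group of 8 heavy atoms on an aromatic carbon gives a 2.3-fold higher number from compound 1 to compound 3 (0.36 log units; beyond the scatter) in this assay. Nothing on hand accounts for either step.

From the compounds shown here alone, whether the chain step carries over to the core of compound 1 stays open, since the cyclopropylmethoxy partner of compound 1 is absent from this set. Also open, going by these compounds, is how a longer chain, a plain propoxy or a terminal amine on the same oxygen would read.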